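This account rests on a few compounds, and the source may have more. Where it says the series, first, only, none or still open, it means among the compounds named here.

Compound 1 `CN(C)C(=O)c1cc2cnc(Nc3ccc(NC(=O)C4(C(=O)Nc5ccc(Cl)cc5)CC4)cc3)nc2n1C1CCCC1`, compound 2 `CN(C)C(=O)c1cc2cnc(Nc3ccc(NC(=O)C4(C(=O)Nc5ccc(Br)cc5)CC4)cc3)nc2n1C1CCCC1` and compound 3 `Cc1ccc(NC(=O)C2(C(=O)Nc3ccc(Nc4ncc5cc(C(=O)N(C)C)n(C6CCCC6)c5n4)cc3)CC2)cc1` share one core and differ in a single aromatic substituent. In a functional assay on T47D cells (Homo sapiens) for inhibition, read by CCK-8 assay, with a stated time of 72 h, tested at 1 uM (a lower number here means less inhibition of growth, a higher number more inhibition of growth at the concentration tested), compound 1 gives 22.8%, compound 2 gives 21.1% and compound 3 gives 47.9%, the highest of the three. Compound 4 `CN(C)C(=O)c1cc2cnc(Nc3ccc(NC(=O)C4(C(=O)Nc5ccc(O)cc5)CC4)cc3)nc2n1C1CCCC1` differs from compound 3 as follows: hydroxy in place of methyl on an aromatic carbon. This puts hydroxy in place of methyl on an aromatic carbon, para to a large group. The nearest evidence is a number 25.1 percentage points higher from compound 1 to compound 3 (beyond the scatter) and a number 26.8 percentage points higher from compound 2 to compound 3 (beyond the scatter), both modest, while a number 1.7 percentage points lower from compound 1 to compound 2 (within the scatter) lies within the scatter. Among the measured compounds shown here, no measured compound carries hydroxy, so a modest fall is expected only tentatively. The expected change is a number 15.9 percentage points lower from compound 3 to compound 4 (beyond the scatter). For compound 4, the estimated value is 32%, with an expected range of 14% to 52%.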

Compound 4, percent growth inhibition at one concentration: 91.5%
For compound 4 the middle estimate is 59.5 percentage points below the measured one; measured number above the stated range.
By their numbers in this assay, from the lowest: compounds 2 and 1 (each within the scatter of the next); then compound 3; then compound 4.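

Among the groups shown on this aromatic carbon, para to a large group, hydroxy stands apart in this assay: the exchange for methyl gives a number 43.6 percentage points higher from compound 3 to compound 4 (beyond the scatter), and the exchanges for the halogens give a number 70.4 percentage points higher from compound 2 to compound 4 (beyond the scatter) and a number 68.7 percentage points higher from compound 1 to compound 4 (beyond the scatter). The earlier compounds shown here showed only methyl above bromo and chloro, whereas this exchange of one heavy atom, which adds a hydrogen-bond donor and acceptor, shows a far wider span of growth inhibition at this position. Nothing available here accounts for the size of these steps.

The compounds shown leave open whether an amine or a methoxy group at this position would match hydroxy. They also leave open whether hydroxy would give a similar step on another part of the shared core.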